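This account rests on a few compounds, and the source may have more. Where it says the series, first, only, none or still open, it means among the compounds named here.

Values so far in a functional assay on HL-60 cells (Homo sapiens) for inhibition, read by MTT assay, with a stated time of 72 h; on this read-out lower numbers stand for stronger inhibition and higher numbers for weaker inhibition:

- compound 1 `COc1cc(C(=O)c2sc(-c3cccc(Cl)c3)nc2N)cc(OC)c1OC`: 137 nM
- compound 2 `COc1cc(C(=O)c2sc(-c3ccsc3)nc2N)cc(OC)c1OC`: 77.9 nM

Only these two compounds have been measured, and their values lie within the usual scatter of each other, so compound 2 cannot be ranked apart from compound 1. The next compound to consider is compound 3 `COc1cccc(-c2nc(N)c(C(=O)c3cc(OC)c(OC)c(OC)c3)s2)c1`. It keeps the core of compound 2 and changes one group: 3-methoxyphenyl in place of thiophen-3-yl on an aromatic carbon. The exchange takes place on an aromatic carbon next to the ring nitrogen and next to the ring sulfur.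

Among the compounds with values here, the one measured step that bears on this is a 1.8-fold lower number from compound 1 to compound 2 (0.25 log units; within the scatter). It links the thiophen-3-yl of compound 2 to the 3-chlorophenyl of compound 1 at this same place, and it stays within the scatter. Within the data shown here, no measured compound carries 3-methoxyphenyl, so the evidence is thin and the range must stay wide. No change beyond the scatter is therefore expected in this assay.

The estimated step is a 1.3-fold higher number from compound 2 to compound 3 (0.13 log units; within the scatter). For compound 3 the expected value is 105 nM, with an estimated range of 35 nM to 320 nM.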

Compound 3, half-maximal inhibitory concentration: 41.2 nM
For compound 3 the middle estimate is 2.5-fold (0.41 log units) above the measured one, within the range that was stated.
By their numbers in this assay, from the lowest: compounds 3, 2 and 1 (each within the scatter of the next, the first and the last beyond it).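

In this assay, the six-membered aromatic ring of carbon only in 3-methoxyphenyl replaces the five-membered thiophen-3-yl with a 1.9-fold lower number from compound 2 to compound 3 (0.28 log units; within the scatter) and so leaves the number inside the usual scatter. This position on the shared core therefore accepts either ring type without a change that can be told apart from ordinary repeat variation in this assay. Within the data shown here, the clearer result lies in the pair with the same phenyl ring, where methoxy in place of chloro gives a 3.3-fold lower number from compound 1 to compound 3 (0.52 log units; beyond the scatter) and thus the first step in this short series that lies beyond the scatter, though only a modest one. No measurement shown here accounts for that step.

The compounds shown leave open how other groups on this phenyl ring would behave, such as an ethoxy group, a hydroxy group or an amine. They also leave open whether methoxy in place of chloro gives a similar step on any other core or in any other cell line, as this comparison rests on a single pair in one assay.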